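Swapping trifluoromethoxy for trifluoromethyl: expected solubility

This account rests on a few compounds, and the source may have more. Where it says the series, first, only, none or still open, it means among the compounds named here.

Compound 1 `O=C(Nc1ccc(C(F)(F)F)c(F)c1)NC1CCN(C(=O)C2(C(F)(F)F)CC2)CC1`: 0.08 ug/mL
Compound 2 `O=C(Nc1ccc(C(F)(F)F)c(F)c1)NC1CCN(C(=O)C2CC2)CC1`: 0.46 ug/mL
Compound 3 `O=C(Nc1ccc(OC(F)(F)F)c(F)c1)NC1CCN(C(=O)[C@@H]2CCOC2)CC1`: 61 ug/mL

These three compounds were tested in a physicochemical assay for solubility, read by mass spectrometry, in phosphate buffer, with a stated time of 24 h, at pH 7.4; a higher number here means a more soluble compound, a lower number a less soluble compound. Compound 3 stands highest of the three numbers by a wide margin: compound 2 lies a long way beneath it, and compound 1 lies further still, both gaps well beyond the scatter. Compound 1 and compound 2 carry the same aryl trifluoromethyl group as compound 4 and share the shared core; compound 3 carries trifluoromethoxy instead and a different amide ring.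

Among the compounds with values here, the one measured step, a 5.8-fold higher number from compound 1 to compound 2 (0.76 log units; beyond the scatter), concerns a saturated ring carbon, not the aromatic ring, so it does not bear directly on the change at hand. The unmeasured compound 4 `O=C(Nc1ccc(C(F)(F)F)c(F)c1)NC1CCN(C(=O)[C@@H]2CCOC2)CC1` differs from compound 3 in one place: trifluoromethyl in place of trifluoromethoxy on an aromatic carbon. The change sits on an aromatic carbon ortho to a fluoro group and para to a large group.

Within the data shown here, with no matching step to lean on, the expectation rests on the gap between compound 3 and the two trifluoromethyl compounds. A downward step of a 3.1-fold lower number from compound 3 to compound 4 (0.48 log units; beyond the scatter) is expected in this assay, beyond the scatter but smaller than that gap. Compound 4 is estimated at 20 ug/mL, with a range from 5 ug/mL to 60 ug/mL.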

Compound 4, solubility: 1.9 ug/mL
Compound 4: the middle estimate sits 11-fold (1.02 log units) above what was measured, outside the stated range (below it).
By their numbers in this assay, from the lowest: compound 1; then compound 2; then compound 4; then compound 3.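

Within the data shown here, at this aromatic carbon, ortho to a fluoro group and para to a large group, the earlier compounds offered no matched pair; in this assay, trifluoromethyl in place of trifluoromethoxy now gives a 32-fold lower number from compound 3 to compound 4 (1.51 log units; beyond the scatter) as a large step, with the rest of the molecule unchanged. Among these compounds, compound 4 also links the amide end to the earlier compounds with the aromatic group held as trifluoromethyl: oxolan-3-yl in place of cyclopropyl gives a 4.1-fold higher number from compound 2 to compound 4 (0.62 log units; beyond the scatter) as a modest step, and oxolan-3-yl in place of 1-(trifluoromethyl)cyclopropyl gives a 24-fold higher number from compound 1 to compound 4 (1.38 log units; beyond the scatter) as a large one, so both ends of these molecules move the number. Nothing shown here accounts for the size of any of these steps.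

On these data alone, it remains open whether trifluoromethoxy would give a step of similar size with cyclopropyl or 1-(trifluoromethyl)cyclopropyl on the carbonyl carbon, since this swap is seen with oxolan-3-yl alone. Also open, as far as these compounds go, is where this assay would place a methoxy group, a nitrile or an amine on this same aromatic carbon, relative to the two fluorinated groups.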